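The source may report more compounds than this note shows. Statements on the series, on what has been measured and on what is new or still open speak of the compounds shown alone.

Measured compounds:
compound 1 `O=S(=O)(NCCCNc1nccc(-c2c(-c3cccc(F)c3)nc3sccn23)n1)c1ccc(Cl)cc1`, 5900 nM
compound 2 `O=S(=O)(NCCNc1nccc(-c2c(-c3cccc(F)c3)nc3sccn23)n1)c1cccc(F)c1`, 14900 nM

Among the measured compounds shown here, compound 2 stands with the higher of the two numbers in a functional assay on A-375 cells (Homo sapiens) for cytotoxicity, read by MTT assay; a higher number here means a weaker inhibitor, a lower number a stronger inhibitor; the only step that bears on it, a 2.5-fold higher number from compound 1 to compound 2 (0.40 log units; beyond the scatter), is modest but beyond the scatter. Compound 3 `Cc1ccc(S(=O)(=O)NCCCNc2nccc(-c3c(-c4cccc(F)c4)nc4sccn34)n2)cc1` carries (((4-methylphenyl)sulfonyl)amino)methyl in place of ((3-fluorophenyl)sulfonyl)amino on a saturated chain carbon, two bonds along the chain from a nitrogen on an aromatic ring, which restores the chain length of compound 1 and exchanges only the aryl substituent. Since the step from compound 1 to compound 2 undid roughly this chain change, the step is expected to run back down, a 2.1-fold lower number from compound 2 to compound 3 (0.33 log units; beyond the scatter). Compound 3 is therefore estimated at 7000 nM, within a range of 3000 nM to 18000 nM.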

Compound 3, half-maximal inhibitory concentration: 8380 nM
Compound 3: middle estimate off by 1.2-fold (0.08 log units), on the low side; the range from low to high includes it.
By their numbers in this assay, from the lowest: compounds 1, 3 and 2 (each within the scatter of the next, the first and the last beyond it).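

Methyl in place of chloro on an aromatic carbon gives a 1.4-fold higher number from compound 1 to compound 3 (0.15 log units; within the scatter) in this assay and so leaves the two groups unresolved at this position. The exchange of ((3-fluorophenyl)sulfonyl)amino for (((4-methylphenyl)sulfonyl)amino)methyl gives a 1.8-fold lower number from compound 2 to compound 3 (0.25 log units; within the scatter) and is also unresolved, although the same kind of exchange in the other direction gave a 2.5-fold higher number from compound 1 to compound 2 (0.40 log units; beyond the scatter) as a step beyond the scatter. Nothing available explains these numbers.

From the compounds shown here alone, whether a methoxy group or an amine on that aromatic carbon would move the number remains open. So does the effect of a longer chain.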